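Sulfonamide series: chloro in place of ethyl on the aryl

The source may hold more compounds than are shown below. What is called first, only, known or untested is meant among the compounds shown, and "the series" means these compounds.

Numbers in a functional assay on HT-29 cells (Homo sapiens) for antiproliferative activity, read by sulforhodamine B assay, with a stated time of 48 h (on this read-out higher numbers stand for weaker inhibition and lower numbers for stronger inhibition), so far:
- compound 1 `CCc1ccc(NS(=O)(=O)c2ccc(N3CCNC3=O)cc2)cc1`: 660 nM
- compound 2 `CCCCOc1ccc(NS(=O)(=O)c2ccc(N3CCNC3=O)cc2)cc1`: 630 nM
- compound 3 `O=C1NCCN1c1ccc(S(=O)(=O)Nc2cccc(Cl)c2)cc1`: 55 nM

Compound 1 gives the highest number of the three; compound 2 lies beside it, with a 1.0-fold lower number from compound 1 to compound 2 (0.02 log units; within the scatter) within the scatter, while compound 3 sits far off, with a 12-fold lower number from compound 1 to compound 3 (1.08 log units; beyond the scatter) beyond it.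

The next compound, compound 4 `O=C1NCCN1c1ccc(S(=O)(=O)Nc2ccc(Cl)cc2)cc1`, differs from compound 1 as follows: chloro in place of ethyl on an aromatic carbon. Within the data shown here, two measured steps bear on this. The step from compound 1 to compound 2 shows that swapping one group for another at this position of the ring need not move this assay at all. The step from compound 1 to compound 3 shows that a chlorophenyl in place of the 4-ethylphenyl can lower the number greatly, although there it is 3-chlorophenyl, whereas compound 4 carries 4-chlorophenyl. Given a 12-fold lower number from compound 1 to compound 3 (1.08 log units; beyond the scatter) as the only chloro-bearing reference, a lower number is expected for compound 4, probably smaller in size than that step; the chlorophenyl is not the same one. The expected step is a 4.4-fold lower number from compound 1 to compound 4 (0.64 log units; beyond the scatter). For compound 4 the estimate is 150 nM, within 50 nM to 450 nM.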

Compound 4, half-maximal inhibitory concentration: 220 nM
For compound 4 the middle estimate is 1.5-fold (0.17 log units) below the measured one; the measured number falls inside the stated range.
By their numbers in this assay, from the lowest: compound 3; then compound 4; then compounds 2 and 1 (each within the scatter of the next).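

In this assay, the group at this place does move the number after all: chloro in place of ethyl gives a 3.0-fold lower number from compound 1 to compound 4 (0.48 log units; beyond the scatter), and chloro in place of butoxy gives a 2.9-fold lower number from compound 2 to compound 4 (0.46 log units; beyond the scatter), whereas ethyl and butoxy themselves could not be told apart. The place of the chloro on the ring matters as well, since 4-chlorophenyl in place of 3-chlorophenyl gives a 4.0-fold higher number from compound 3 to compound 4 (0.60 log units; beyond the scatter), so the large drop seen with 3-chlorophenyl is not carried by the presence of chloro alone. Nothing measured here gives a reason for either difference.

On these data alone, it remains open whether a bromo or a carboxylic acid in place of the chloro would read like the chloro or like ethyl and butoxy. Also open, as far as these compounds go, is whether moving a group other than chloro from the 4-chlorophenyl arrangement to the 3-chlorophenyl one gives a step of like direction.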